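Hexyl removal on the shared core, cytotoxicity notes

The compounds below may be only part of what the source reports. "The series", "measured", "known", "first", "only" and "open" are said of these compounds alone.

Measured so far:
Compound 1 `CCCCCCc1cc2cn(COCCO)c(=O)nc2o1`: in a functional assay on HEL cells (Homo sapiens) (on this read-out lower numbers stand for higher toxicity in this test and higher numbers for lower toxicity in this test), compound 1 gives > 200000 nM, a limit of the assay.
Compound 2 `CCCCCCc1cc2cn(COCCO)c(O)nc-2n1`: in this assay compound 2 gives > 200000 nM, a limit of the assay.
Compound 3 `OCCOCn1cc2ccnc-2nc1O`: in this assay compound 3 gives > 200000 nM, a limit of the assay.

Compound 1 stands only at a limit, and the two further values are limits as well; all three sit at the limit of > 200000 nM in this assay, at which 3 of the 3 values shown sit. Compound 4 `O=c1nc2occc2cn1COCCO` is not yet measured. From compound 1 it differs by hydrogen in place of hexyl on an aromatic carbon. Going by the values given here, the one comparable measured step, a step that the two limits leave unreadable from compound 2 to compound 3, has no readable size. Among the compounds with values here, no measured step therefore points to a change beyond the scatter in this assay. For compound 4 the expected step is a step that the limit leaves unreadable from compound 1 to compound 4. Compound 4 is expected at 300000 nM, within 100000 nM to 1000000 nM, most probably again reported as a limit.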

Compound 4, half-maximal cytotoxic concentration: > 200000 nM
Compound 4 gave a limit, no number (the forecaster's own chance of this, stated with the estimate: 85%); the middle value does not contradict the limit.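

Compound 1 and compound 4 both stand at a limit in this assay, so the step between them cannot be read: the limit of > 200000 nM in this assay, at which 4 of the 4 values shown sit.

The compounds shown leave open whether hexyl or hydrogen on this aromatic carbon makes any difference to toxicity in this assay.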